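A few compounds are considered here, and "the series" means these few. Any claim that something is new, unique, unknown or untested is made for them only; others in the source may bear on it.

Of the compounds shown here, three have been tested in a functional assay on SH-SY5Y cells (Homo sapiens) for cytotoxicity, read by MTT assay, with stated times of 8 h, 30 min and 12 h, tested at 0.5 uM; on this read-out higher numbers stand for a stronger effect at the one concentration tested and lower numbers for a weaker effect. Compound 1, `N=C(NCc1ccccc1)[C@@H]1CCC(=O)N1Cc1ccccc1`, gives 27.9% in this assay. Compound 2, `COc1ccc(CNC(=N)[C@@H]2CCC(=O)N2Cc2ccccc2)cc1`, gives 23.6%, and the step of a number 4.3 percentage points lower from compound 1 to compound 2 (within the scatter) is the one that separates them. Compound 3, `COc1ccc(CNC(=N)[C@@H]2CCC(=O)N2Cc2ccccc2[N+](=O)[O-])cc1`, gives 21.1%; it differs from compound 2 by a single change, (nitro in place of hydrogen on an aromatic carbon), and that change made the step of a number 2.5 percentage points lower from compound 2 to compound 3 (within the scatter). All three numbers therefore sit close together, and none of them can be called stronger or weaker than another.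

Compound 4, `N=C(NCc1ccccc1)[C@@H]1CCC(=O)N1Cc1ccc([N+](=O)[O-])cc1`, has not yet been measured. It differs from compound 1 by nitro in place of hydrogen on an aromatic carbon. This is the same kind of change that was made from compound 2 to compound 3, but not the same one: in compound 3 the nitro sits ortho to a large group, while in compound 4 it sits para to a large group. The cores also differ: compound 1 stands apart from compound 2 by hydrogen in place of methoxy on an aromatic carbon.

For the measured compounds named here, because the only measured example of this kind of change gave a number 2.5 percentage points lower from compound 2 to compound 3 (within the scatter), the step from compound 1 to compound 4 is expected to be small, about a number 1.9 percentage points lower from compound 1 to compound 4 (within the scatter). On that basis compound 4 is estimated to give 26% in this assay, most likely between 16% and 36%.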

Compound 4, a percentage reported as activity, at one concentration (the size of the read-out at that concentration, not a potency): 24%
For compound 4 the middle estimate is 2 percentage points above the measured one; low and high end bracket the measured number.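

Replacing a hydrogen on the aromatic ring with a nitro group on the core of compound 1 gives a number 3.9 percentage points lower from compound 1 to compound 4 (within the scatter) in this assay. Set beside the earlier example of this change, the result on the second core gives no sign that the core matters: the same change on two cores in this assay, a number 2.5 percentage points lower (within the scatter) from compound 2 to compound 3 and a number 3.9 percentage points lower (within the scatter) from compound 1 to compound 4, 1.4 percentage points apart, within the scatter of two such steps The comparison rests on only two pairs, however, and both steps lie within the scatter, so it does not show that a nitro group moves this read-out in either direction, and it cannot establish that a real effect carries from one core to another, especially as the nitro group of compound 4 sits para to a large group while that of compound 3 sits elsewhere on its ring.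

The compounds shown leave open whether an amine or a carboxylic acid at this place on the aromatic ring would produce a step beyond the scatter. They also leave open whether a longer chain between the aromatic ring and the rest of the molecule would separate any of these compounds from the others.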